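Trimming the Azetidine to a Bare Amino Group

This account rests on a few compounds, and the source may have more. Where it says the series, first, only, none or still open, it means among the compounds named here.

Compound 1 `O=C(CCc1ccc(C(F)(F)F)cc1)Nc1ccc2nc(N3CCC3)ccc2c1` gives 56 nM in a functional assay on HEK293 cells for activation of melanin-concentrating hormone receptor 1 (Rattus norvegicus), read by inositol phosphate accumulation (on this read-out lower numbers stand for an effect already at smaller amounts and higher numbers for an effect only at larger amounts of compound), the lowest of the two single numbers in hand. Compound 2 `CC1CCCN1c1ccc2cc(NC(=O)CCc3ccc(C(F)(F)F)cc3)ccc2n1` gives 270 nM, and compound 3 `O=C(CCc1ccc(C(F)(F)F)cc1)Nc1ccc2nc(N3CCCC3)ccc2c1` gives 320 nM; 320 nM (2 entries) in this assay. Among the measured compounds shown here, the one recorded step, a 4.8-fold higher number from compound 1 to compound 2 (0.68 log units; beyond the scatter), came with 2-methylpyrrolidin-1-yl in place of azetidin-1-yl on an aromatic carbon. Compound 4 `Nc1ccc2cc(NC(=O)CCc3ccc(C(F)(F)F)cc3)ccc2n1` goes the other way: amino in place of azetidin-1-yl on an aromatic carbon. That step and the values of compound 3 both accompany a larger ring and a higher number; nothing in hand shows what removing the ring altogether does. A modest rise is therefore expected, a 2.7-fold higher number from compound 1 to compound 4 (0.43 log units; beyond the scatter), with wide uncertainty. Compound 4 is estimated at 150 nM in this assay, within 40 nM to 600 nM.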

Compound 4, half-maximal effective concentration: 720 nM
Compound 4: middle estimate off by 4.8-fold (0.68 log units), on the low side, outside the stated range (above it).
By their numbers in this assay, from the lowest: compound 1; then compound 2; then compound 4.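

In this assay, the bare amino group brings a 13-fold higher number from compound 1 to compound 4 (1.11 log units; beyond the scatter), and it also ends above the 2-methylpyrrolidin-1-yl compound, with a 2.7-fold higher number from compound 2 to compound 4 (0.43 log units; beyond the scatter). At this position next to the ring nitrogen, the trend from azetidin-1-yl to the larger 2-methylpyrrolidin-1-yl therefore does not mean that a smaller group gives a lower number, as compound 4 goes against it. Nothing given here explains the rise. The change removes the ring and adds a hydrogen-bond donor together, and the compounds shown cannot separate the two. A dimethylamino group, with no ring and no such donor, would address that question.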